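A Halogen Swap on a Shared Core, Awaiting Measurement

The source may hold more compounds than are shown below. What is called first, only, known or untested is meant among the compounds shown, and "the series" means these compounds.

Of the compounds shown here, three built on one shared core have so far been tested in a functional assay on the whole organism (strain Swiss) with Mus musculus as the target, in the maximal electroshock model, with a stated time of 2 h, at a dose of 100 mg/kg by the intraperitoneal route; a lower number here means a weaker effect, a higher number a stronger effect of the compound at the dose given. Compound 1 `COCC(C(=O)N1CCN(c2cccc(C(F)(F)F)c2)CC1)N1C(=O)CCC1=O` gives 0% in this assay. Compound 2 `CC(C(=O)N1CCN(c2ccc(Cl)cc2)CC1)N1C(=O)CCC1=O` gives 0% in this assay, and compound 3 `CCC(C(=O)N1CCN(c2ccccc2F)CC1)N1C(=O)CCC1=O` gives 0% in this assay. On these numbers compound 2 stands level with compounds 1 and 3 at the digits shown: its nearest neighbour is compound 1, with no change within the scatter, and its furthest is compound 3, also with no change within the scatter. None of the three shows any effect at the dose used.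

Compound 4 `CC(C(=O)N1CCN(c2cccc(F)c2)CC1)N1C(=O)CCC1=O` has not yet been measured. It differs from compound 2 in a single place: 3-fluorophenyl in place of 4-chlorophenyl on an amine nitrogen in a ring. For the measured compounds named here, no pair of measured compounds differs in only one place, so no measured step shows how much such a change can move the read-out. With every measured compound at the same level and with no effect seen anywhere, the expected step from compound 2 to compound 4 is none beyond the scatter, that is no change at the digits printed from compound 2 to compound 4 (within the scatter). Compound 4 is therefore estimated to give 0% in this assay, within a range from 0% to 15%.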

Compound 4, a percentage reported as activity, at one dose (the size of the read-out at that dose, not a potency): 0%
Beside the measured number, compound 4's estimate shows no gap at the digits printed; the range from low to high includes it.
By their numbers in this assay, from the lowest: compounds 1, 2, 3 and 4 (each within the scatter of the next).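

In this assay, for the compounds shown here, putting 3-fluorophenyl in place of 4-chlorophenyl gives the first step that can be read between two compounds differing in one place: no change at the digits printed from compound 2 to compound 4 (within the scatter). At this position and dose, then, this swap does not bring out an effect, but a read-out with no effect on either side cannot show whether the two groups differ in any subtler way. The swap also alters both the halogen and where it sits on the phenyl ring, and no measurement explains the outcome or separates these two parts of the change.

The compounds shown leave open whether any group on this amine nitrogen can produce a measurable effect, such as a benzyl group or a phenyl ring carrying a methoxy group. Since all the values shown sit at the same level, they also leave open which parts of the shared core matter for activity in this model.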